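A few compounds are considered here, and "the series" means these few. Any claim that something is new, unique, unknown or untested is made for them only; others in the source may bear on it.

Compound 1: `c1cc(-c2cn[nH]c2)c2c(c1)C(c1ncc[nH]1)CC2` — in a functional assay on CHO cells for agonist activity at Alpha-1B adrenergic receptor (Homo sapiens), read by FLIPR and calcium flux (a higher number here means that more compound is needed for the effect, a lower number that less compound is needed), compound 1 gives > 10000 nM, which is a limit of the assay rather than a number.
Compound 2: `Clc1ccc2c(c1-c1cn[nH]c1)CCC2c1ncc[nH]1` — in this assay compound 2 gives > 10000 nM, again a limit.
Compound 3: `c1ccc2c(c1)CCCC2c1ncc[nH]1` — in this assay compound 3 gives 791 nM.

Compound 1 therefore stands at the limit of > 10000 nM in this assay, at which 2 of the 3 values shown sit, and only a limit is known for it. For the measured compounds named here, the one measured step that starts from compound 1, a step that the two limits leave unreadable from compound 1 to compound 2, runs from one limit to another and its size cannot be read. Going by the values given here, compound 3, built on a different core and carrying no aryl substituent, is the only compound of the three that gives a number.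

The unmeasured compound 4, `c1cc(-c2ncco2)c2c(c1)C(c1ncc[nH]1)CC2`, differs from compound 1 in one place: 1,3-oxazol-2-yl in place of 1H-pyrazol-4-yl on an aromatic carbon. Among the compounds with values here, no measured step changes this group, so nothing among the measured compounds tells how the assay responds to it. What is known is that compound 1 sits at a limit and that compound 2, which keeps the same core and the same group, sits at the same limit. Compound 4 is thus expected to remain weak, with a good chance that only a limit is reported again; the expected step of an at least 1.2-fold lower number from compound 1 to compound 4 (0.09 log units; that floor lies within the scatter) is uncertain. Compound 4 is estimated at 8000 nM, within 2000 nM to 30000 nM.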

Compound 4, half-maximal effective concentration: > 10000 nM
Compound 4: no number, only a limit; the forecaster's own chance of this, stated with the estimate: 55%; middle value at least 1.2-fold (0.09 log units) away from the limit.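

In this assay compound 4 gives > 10000 nM, which is a limit and not a number. Compound 1 is also known only as a limit, and the step from compound 1 to compound 4 cannot be read. The compounds shown leave open how 1,3-oxazol-2-yl and 1H-pyrazol-4-yl compare on this core, because most values sit at one limit: the limit of > 10000 nM in this assay, at which 3 of the 4 values shown sit.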